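The compounds below may be only part of what the source reports. "The series", "measured", "known", "first", "only" and "open" are said of these compounds alone.

Measured so far:
- compound 1 `CS(=O)(=O)Nc1ccc2c(c1)S(=O)(=O)N=C(C1=C(O)C3CCCC3N(Cc3ccccn3)C1=O)N2`: 76%
- compound 2 `Cc1cc(CN2C(=O)C(C3=NS(=O)(=O)c4cc(NS(C)(=O)=O)ccc4N3)=C(O)[C@H]3CCC[C@H]32)ccc1F`: 66%
- compound 3 `CS(=O)(=O)Nc1ccc2c(c1)S(=O)(=O)N=C(C1=C(O)C3CCCCC3N(Cc3ccc(F)cc3)C1=O)N2`: 81%

In an ADME assay on microsomes from liver (Homo sapiens) for metabolic stability, with a stated time of 60 min, tested at 1 uM (a lower number here means that less of the compound is left, a higher number that more of the compound is left), compound 1 gives 76%. Compound 3 gives 81% and compound 2 gives 66%; both differences from compound 1 lie within the usual scatter, so the three measured compounds cannot be told apart on this read-out.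

Compound 4 `CS(=O)(=O)Nc1ccc2c(c1)S(=O)(=O)N=C(C1=C(O)C3CCCC3N(Cc3ccc(Cl)cc3)C1=O)N2` differs from compound 1 in one place: 4-chlorophenyl in place of pyridin-2-yl on a saturated chain carbon bound to an amide-type nitrogen in a ring. Going by the values given here, no measured pair shows this change, so the expectation rests on compound 1 alone. The step from compound 1 to compound 4 is expected to be small, a number 4 percentage points lower from compound 1 to compound 4 (within the scatter), and not beyond the scatter. Compound 4 is therefore estimated at 72%, in the range 55% to 88%.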

Compound 4, percent of the compound remaining: 90%
Compound 4: middle estimate off by 18 percentage points, on the low side, outside the stated range (above it).
By their numbers in this assay, from the lowest: compounds 2, 1, 3 and 4 (each within the scatter of the next, the first and the last beyond it).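

In this assay, 4-chlorophenyl in place of pyridin-2-yl on a saturated chain carbon bound to an amide-type nitrogen in a ring gives a number 14 percentage points higher from compound 1 to compound 4 (beyond the scatter). Going by these compounds alone, this shows that the aromatic ring at this place can move the read-out, which the earlier compounds, differing in more than one place, could not show. The finding rests on this single pair.

From the compounds shown here alone, whether the chlorine or the exchange of the ring nitrogen for carbon carries the step stays open, as does the reading for a plain benzyl group or an amine on the phenyl ring. No measurement at hand bears on the cause of the step.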